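Phenyl for Methyl on a Hexafluorocarbinol Phenol

This account rests on a few compounds, and the source may have more. Where it says the series, first, only, none or still open, it means among the compounds named here.

Compound 1 `Cc1ccc(O)c(C(O)(C(F)(F)F)C(F)(F)F)c1` gives 207000 nM in an assay on isolated protein for inhibition of receptor-type tyrosine-protein phosphatase C (Homo sapiens), read by spectrophotometry; on this read-out lower numbers stand for stronger inhibition and higher numbers for weaker inhibition. Compound 3 `CC(C)c1ccc(NC(=O)COc2ccc3cc(C(O)(C(F)(F)F)C(F)(F)F)c(O)cc3c2)cc1` gives 7800 nM in this assay. Compound 2 `Oc1cc(-c2ccccc2)ccc1C(O)(C(F)(F)F)C(F)(F)F` gives > 500000 nM in this assay, a limit rather than a number, namely (the limit of > 500000 nM in this assay, at which 1 of the 3 values shown sits).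

Among the two numbers, compound 1 stands at the higher one and compound 3 at the lower, a gap beyond the scatter. Compound 4 `Oc1ccc(-c2ccccc2)cc1C(O)(C(F)(F)F)C(F)(F)F` differs from compound 1 by phenyl in place of methyl on an aromatic carbon. Within the data shown here, no measured step of this kind exists here. Compound 2 also carries a phenyl and sits at a limit, so compound 4 is expected to show either no step beyond the scatter or a step toward weaker inhibition, as a 1.4-fold higher number from compound 1 to compound 4 (0.16 log units; within the scatter). Compound 4 is estimated at 300000 nM, within 100000 nM to 900000 nM.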

Compound 4, half-maximal inhibitory concentration: > 500000 nM
Compound 4 ended at the assay's limit; the forecaster's own chance of this, stated with the estimate: 40%; middle value at least 1.6-fold (0.22 log units) from the limit.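

In this assay, among these compounds, phenyl in place of methyl at this position, para to a hydroxy group, gives an at least 2.4-fold higher number from compound 1 to compound 4 (0.38 log units; beyond the scatter), the first measured step on this core, and it runs toward weaker inhibition. Compound 4 gives > 500000 nM, a limit of the assay and not a number, so the step has a lower bound but no exact size. Compound 4 now shares this limit with compound 2: the limit of > 500000 nM in this assay, at which 2 of the 4 values shown sit.

As far as these compounds go, whether an ethyl, a methoxy or an amine at this position would retain the inhibition seen with methyl remains open. So does whether a phenyl carrying a carboxylic acid would restore it.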